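This account rests on a few compounds, and the source may have more. Where it says the series, first, only, none or still open, it means among the compounds named here.

Working notes on the series.

Three compounds of the shared core have been run in a functional assay on the whole organism (strain Swiss albino) with Mus musculus as the target, in the forced swim test, with a stated time of 5 min, at a dose of 0.5 mg/kg by the intraperitoneal route; on this read-out higher numbers stand for more inhibition at the one dose given (going by the name of the read-out) and lower numbers for less inhibition. Compound 1 `COc1ccc(-c2cc3cc(C4C(C#N)=C(N)OC5=C4C(=O)CC(C)(C)C5)cc(C)c3oc2=O)cc1OC` gives 10.4%. Among the measured compounds shown here, compound 3 `COc1cc(-c2cc3cc(C4C(C#N)=C(N)OC5=C4C(=O)CC(C)(C)C5)cc(C)c3oc2=O)cc(OC)c1OC` gives 6.37%; the one measured step, methoxy in place of hydrogen on an aromatic carbon, is a number 4 percentage points lower from compound 1 to compound 3 (within the scatter). Compound 2 `COc1cc(-c2cc3cc(C4C(C#N)=C(N)OC5=C4C(=O)CCC5)cc(C)c3oc2=O)cc(OC)c1OC` gives 5.22%; it holds the lowest of the three numbers, yet its gap to compound 3 and its gap to compound 1 both lie within the scatter, so no order among the three can be read from these numbers.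

The next compound, compound 4 `CCC(C)c1cc(C2C(C#N)=C(N)OC3=C2C(=O)CCC3)cc2cc(-c3cc(OC)c(OC)c(OC)c3)c(=O)oc12`, differs from compound 2 in one place: sec-butyl in place of methyl on an aromatic carbon. The methyl leaves and a sec-butyl enters, on an aromatic carbon of a six-membered carbon ring in a fused system of two rings, ortho to a fused ring and meta to a large group. For the measured compounds named here, no measured pair changes this group, so the only step on record, from compound 1 to compound 3, is of a different kind and, being within the scatter, gives no direction. Going by the values given here, with every number so far at the low end of this assay and no step beyond the scatter, the expected step to compound 4 is a number 1.8 percentage points higher from compound 2 to compound 4 (within the scatter), that is, none beyond the scatter.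

Compound 4 is therefore estimated at 7% in this assay, with a range from 0% to 16%.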

Compound 4, a percentage reported as inhibition, in the whole organism at one dose (the size of the read-out at that dose, not a potency): 56.1%
Beside the measured number, compound 4's estimate is 49.1 percentage points below it; measured number above the stated range.
By their numbers in this assay, from the lowest: compounds 2, 3 and 1 (each within the scatter of the next); then compound 4.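

In this assay, among the compounds shown here, sec-butyl in place of methyl on an aromatic carbon, ortho to a fused ring and meta to a large group, gives a number 50.9 percentage points higher from compound 2 to compound 4 (beyond the scatter), the first step on record that lies beyond the scatter. For the compounds shown here, this place on the shared core, which the one earlier measured pair did not touch, therefore responds strongly to the group it carries: the group goes from 1 heavy atom to 4 heavy atoms, all carbon, with no ring, no hydrogen-bond donor or acceptor and no net charge on either side. No measurement at hand bears on why the number rises this far, and the finding rests on this single pair.

Whether the step follows from the size of the group or from its branching stays open, since the compounds shown hold no ethyl, isopropyl, n-butyl or tert-butyl group at this place. Also open, from the compounds shown here alone, are how an amine or a hydroxyl group would fare here, and whether sec-butyl gives a similar step on the core of compound 1.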